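The source may report more compounds than this note shows. Statements on the series, on what has been measured and on what is new or still open speak of the compounds shown alone.

Measured so far in a functional assay on MCF7 cells (Homo sapiens) for cytotoxicity, read by MTT assay, with a stated time of 72 h; a lower number here means a stronger inhibitor, a higher number a weaker inhibitor:
- compound 1 `COc1cccc(/C=C2\CCC/C(=C\c3ccc(Cl)cc3)C2=O)c1OC` gives 10300 nM
- compound 2 `COc1cccc(/C=C2\CCC/C(=C\c3ccc(Br)cc3)C2=O)c1OC` gives 13800 nM
- compound 3 `COc1cccc(/C=C2\CCC/C(=C\c3cccc(OC)c3OC)C2=O)c1` gives 5900 nM

Two steps show where compound 3 stands. The first is a 1.7-fold lower number from compound 1 to compound 3 (0.24 log units; within the scatter), so those two compounds cannot be told apart. The second is a 2.3-fold lower number from compound 2 to compound 3 (0.37 log units; beyond the scatter), a modest gap that does clear the scatter.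

Compound 4 `COc1cccc(/C=C2\CCC/C(=C\c3cccc(Cl)c3Cl)C2=O)c1OC` has not been measured yet. It differs from compound 3 by one group: 2,3-dichlorophenyl in place of 3-methoxyphenyl on a double-bonded chain carbon bound to a double-bonded ring carbon. In words, this is 2,3-dichlorophenyl in place of 3-methoxyphenyl on a double-bonded chain carbon bound to a double-bonded ring carbon.

This change runs opposite to the two steps above, since a halogen-bearing phenyl returns to that place. Exchanging one halogen for the other made little difference, as a 1.3-fold higher number from compound 1 to compound 2 (0.13 log units; within the scatter) shows. With a halogen-bearing phenyl at that place, compound 1 gives 10300 nM and compound 2 gives 13800 nM, so a somewhat higher number than for compound 3 is expected. Among the measured compounds shown here, no measured compound carries the 2,3-dichlorophenyl group, however, so the size remains uncertain. The expected change is small, namely a 1.5-fold higher number from compound 3 to compound 4 (0.18 log units; within the scatter), and it may not clear the scatter. For compound 4 the estimate is 9000 nM, with an expected range from 3500 nM to 20000 nM.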

Compound 4, half-maximal inhibitory concentration: > 20000 nM
Compound 4: no number, only a limit (the forecaster's own chance of this, stated with the estimate: 3%); at least 2.2-fold (0.34 log units) between middle value and limit.
By their numbers in this assay, from the lowest: compounds 3, 1 and 2 (each within the scatter of the next, the first and the last beyond it). At a limit, above all of these: compound 4.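

Compound 4 stands only as a limit in this assay: the limit of > 20000 nM in this assay, at which 1 of the 4 values shown sits. Even so, the change at this place, on a double-bonded chain carbon bound to a double-bonded ring carbon, gives an at least 3.3-fold higher number from compound 3 to compound 4 (0.53 log units; beyond the scatter), so replacing 3-methoxyphenyl with 2,3-dichlorophenyl costs activity by a margin that clears the scatter, and the choice of substituted phenyl here clearly matters. The comparisons with the two compounds carrying a single halogen are less decisive, with an at least 1.4-fold higher number from compound 2 to compound 4 (0.16 log units; that floor lies within the scatter) and an at least 1.9-fold higher number from compound 1 to compound 4 (0.28 log units; that floor lies within the scatter). Both floors lie within the scatter. The 2,3-dichlorophenyl group cannot yet be ranked against 4-bromophenyl or 4-chlorophenyl.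

The compounds shown do not reveal how far the true value of compound 4 lies beyond its limit, so the full size of these steps remains unknown. It also remains open how this place would respond to an unsubstituted phenyl, or to a phenyl carrying an amine or a carboxylic acid, since every group shown here is a phenyl bearing only halogen or methoxy substituents.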